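Dichlorophenyl in Place of Cyanophenyl on the Benzyl Ether

A few compounds are considered here, and "the series" means these few. Any claim that something is new, unique, unknown or untested is made for them only; others in the source may bear on it.

Within the data shown here, compound 3 `N#Cc1cccc(COc2ccccc2C(=O)Nc2cccnc2)c1` gives 60700 nM in an assay on lysate for inhibition of phosphatidylcholine:ceramide cholinephosphotransferase 2 (Homo sapiens), read by HPLC, with stated times of 30 min and 2 h (on this read-out lower numbers stand for stronger inhibition and higher numbers for weaker inhibition), the highest of the three numbers so far. Compound 1 `N#Cc1ccccc1COc1ccccc1C(=O)Nc1cccnc1` gives 31800 nM in this assay, and the step of a 1.9-fold higher number from compound 1 to compound 3 (0.28 log units; within the scatter) lies within the scatter. Compound 2 `O=C(Nc1cccnc1)c1ccccc1OCc1cccc(Cl)c1` gives 1400 nM in this assay, and the step of a 43-fold higher number from compound 2 to compound 3 (1.64 log units; beyond the scatter) is large.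

Compound 4 `O=C(Nc1cccnc1)c1ccccc1OCc1c(Cl)cccc1Cl` differs from compound 3 by 2,6-dichlorophenyl in place of 3-cyanophenyl on a saturated chain carbon bound to an oxygen on an aromatic ring. Among the measured compounds shown here, two measured steps bear on this change. The step of a 23-fold lower number from compound 1 to compound 2 (1.36 log units; beyond the scatter) exchanged a cyanophenyl for a chlorophenyl and gave a large drop in the number; the step of a 43-fold higher number from compound 2 to compound 3 (1.64 log units; beyond the scatter) went the other way with a large rise. Both point to chloro on the benzyl ring being associated with lower numbers than cyano, so for compound 4 a large step downward in this assay is expected, a 24-fold lower number from compound 3 to compound 4 (1.39 log units; beyond the scatter). For the measured compounds named here, no measured compound carries two chlorines or the 2,6-substitution pattern, so the range is kept wide. For compound 4 the value in this assay is estimated at 2500 nM, with a range from 400 nM to 20000 nM.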

Compound 4, half-maximal inhibitory concentration: 690 nM
The estimate for compound 4 lay 3.6-fold (0.56 log units) above the measured number, and the stated range covers the measured number.
By their numbers in this assay, from the lowest: compound 4; then compound 2; then compounds 1 and 3 (each within the scatter of the next).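

In this assay, this position tolerates two chlorines on the ring: the large steps (an 88-fold lower number from compound 3 to compound 4 (1.94 log units; beyond the scatter)) and (a 46-fold lower number from compound 1 to compound 4 (1.66 log units; beyond the scatter)) place 2,6-dichlorophenyl far from both cyanophenyl compounds. The step from the single-chlorine ring is much smaller (a 2.0-fold lower number from compound 2 to compound 4 (0.31 log units; beyond the scatter)), so most of the gain is already present in compound 2, although this change alters both the number of chlorines and their placement. Across these four compounds, both chlorophenyl compounds give lower numbers than both cyanophenyl compounds, and none goes against this.

No measurement at hand accounts for these steps. Open, on these data alone, are how a single chlorine on the 2-position would compare with the 2,6-dichlorophenyl ring, and whether a methoxy or an amine on this ring would keep numbers this low.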